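The source may report more compounds than this note shows. Statements on the series, on what has been measured and on what is new or still open speak of the compounds shown alone.

For the measured compounds named here, in a functional assay on MGC-803 cells (Homo sapiens) for antiproliferative activity, read by MTT assay, with a stated time of 72 h (a higher number here means a weaker inhibitor, a lower number a stronger inhibitor), compound 1 (`O=C(N/N=C/c1ccccn1)c1cccc(S(=O)(=O)N2CCOCC2)c1`) gives 81700 nM and compound 2 (`COc1ccc(/C=N/NC(=O)c2cccc(S(=O)(=O)N3CCOCC3)c2)c(O)c1`) gives 2070 nM as the lower of the two numbers measured so far. Compound 3 (`O=C(N/N=C/c1cc(Cl)ccc1O)c1cccc(S(=O)(=O)N2CCOCC2)c1`) has 5-chloro-2-hydroxyphenyl in place of 2-hydroxy-4-methoxyphenyl on a carbon with a double bond to nitrogen. Going by the values given here, the only measured step (a 39-fold lower number from compound 1 to compound 2 (1.60 log units; beyond the scatter)) is large and beyond the scatter, but it replaced pyridin-2-yl, a group that plays no part in this new change. Among the compounds with values here, no measured pair shows what swapping these two hydroxyphenyl groups does, so that step offers only weak guidance. Compound 3 keeps a 2-hydroxy-substituted phenyl, so no step beyond the scatter is expected in this assay and neither direction is favoured. The estimate amounts to an expected 1.2-fold lower number from compound 2 to compound 3 (0.06 log units; within the scatter) on this measure. The estimated value for compound 3 is 1800 nM with an expected range from 500 nM to 7000 nM in this measurement.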

Compound 3, half-maximal inhibitory concentration: 11000 nM
Estimate against measurement, compound 3: 6.1-fold (0.79 log units) below; the whole stated range lies below it.
By their numbers in this assay, from the lowest: compound 2; then compound 3; then compound 1.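

Swapping the two hydroxyphenyl groups on the carbon with a double bond to nitrogen gives a 5.3-fold higher number from compound 2 to compound 3 (0.73 log units; beyond the scatter) in this assay, so keeping the 2-hydroxy group does not by itself hold the activity at this position. The other substituents on the ring matter too. Compared with pyridin-2-yl, 5-chloro-2-hydroxyphenyl still gives a 7.4-fold lower number from compound 1 to compound 3 (0.87 log units; beyond the scatter), a gain that falls short of the one in a 39-fold lower number from compound 1 to compound 2 (1.60 log units; beyond the scatter), and nothing available explains the difference between the two groups.

The swap removes a methoxy group and adds a chlorine at a different ring location in one move, so the effect of each remains unseparated. Also open, on these data alone, is what a plain phenyl would give, which would show whether the hydroxyl group contributes at all, or a phenyl carrying an amine.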